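Swapping Hydroxy for Carbamoyl on a Melatonin Receptor Agonist

A few compounds are considered here, and "the series" means these few. Any claim that something is new, unique, unknown or untested is made for them only; others in the source may bear on it.

Of the compounds shown here, three sharing one core have been measured in a functional assay on cells for agonist activity at melatonin receptor type 1A (Homo sapiens), read by GTPgammaS binding, with a stated time of 30 min; on this read-out lower numbers stand for smaller maximal responses and higher numbers for larger maximal responses. Compound 1 `CC(=O)NCCN(C)c1cccc(OCCCCNC(=O)Oc2cccc(-c3ccccc3)c2)c1` gives 0.64. Compound 2 `CC(=O)NCCN(C)c1cccc(OCCCCCCNC(=O)Oc2cccc(-c3ccccc3)c2)c1`, with a longer chain between the core and the carbamate, gives 0.7. Compound 3 `CC(=O)NCCN(C)c1cccc(OCCCCCCNC(=O)Oc2cccc(-c3cccc(O)c3)c2)c1` gives 0.89, the highest of the three numbers; compound 2 stands nearest, and compound 1 furthest away, both beyond the scatter. Within the data shown here, the only single-point step among the measured compounds is a number 0.19 higher from compound 2 to compound 3 (beyond the scatter), a modest rise on adding a hydroxy to the outer ring.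

Compound 4 `CC(=O)NCCN(C)c1cccc(OCCCCCCNC(=O)Oc2cccc(-c3cccc(C(N)=O)c3)c2)c1` differs from compound 3 in one place: carbamoyl in place of hydroxy on an aromatic carbon. Both the departing hydroxy and the entering carbamoyl carry one hydrogen-bond donor and one acceptor, so a polar group remains on that ring. Among the measured compounds shown here, the step from compound 2 to compound 3 shows that putting such a group there raised the response; there is no measured step showing what happens when one polar group is traded for another. The expectation is therefore that compound 4 keeps most of the response of compound 3, with an estimated step of a number 0.040 lower from compound 3 to compound 4 (within the scatter), inside the scatter. Compound 4 is estimated at 0.85, with a range from 0.65 to 1.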

Compound 4, intrinsic activity: the largest response reached, as a fraction of the reference agonist's: 0.79
Compound 4: the middle estimate sits 0.060 above what was measured; measured number inside the range.
By their numbers in this assay, from the lowest: compounds 1, 2, 4 and 3 (each within the scatter of the next, the first and the last beyond it).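

Trading hydroxy for carbamoyl on the outer ring gives a number 0.10 lower from compound 3 to compound 4 (within the scatter) in this assay, so this ring position takes the larger carbamoyl without a shift that stands clear of the usual scatter. Measured against the unsubstituted ring, carbamoyl gives a number 0.090 higher from compound 2 to compound 4 (within the scatter) while hydroxy gave a number 0.19 higher from compound 2 to compound 3 (beyond the scatter) and only the hydroxy step clears the scatter, so compound 4 cannot be told apart from either compound 2 or compound 3, and the rise seen with hydroxy is not shown to carry over to carbamoyl, even though the two groups match in hydrogen-bond donors and acceptors. No supporting measurement here bears on what lies behind these steps.

The compounds shown leave open whether an amine, a carboxylic acid or a hydroxymethyl group on the same ring carbon would follow hydroxy or stay level with the unsubstituted ring. They also leave open whether hydroxy or carbamoyl would act in the same way on the shorter chain of compound 1 or on a chain longer than that of compound 2.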